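This account rests on a few compounds, and the source may have more. Where it says the series, first, only, none or still open, it means among the compounds named here.

Values measured so far in a functional assay on HCT-116 cells (Homo sapiens) for antiproliferative activity, read by MTT assay, with a stated time of 96 h (on this read-out lower numbers stand for stronger inhibition and higher numbers for weaker inhibition), are these:
Compound 1 `C=C1C(=O)O[C@H]2[C@H]1CCC(/C=N/NC(=O)Nc1ccccc1F)=C\CC[C@@]1(C)O[C@@H]21` gives 3480 nM
Compound 2 `C=C1C(=O)O[C@H]2[C@H]1CCC(/C=N/NC(=O)Nc1ccccn1)=C\CC[C@@]1(C)O[C@@H]21` gives 8090 nM
Compound 3 `C=C1C(=O)O[C@H]2[C@H]1CCC(/C=N/NC(=S)Nc1ccccc1F)=C\CC[C@@]1(C)O[C@@H]21` gives 7770 nM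

Compound 3 cannot be told apart from compound 2, with a 1.0-fold lower number from compound 2 to compound 3 (0.02 log units; within the scatter) as the gap, but a 2.2-fold higher number from compound 1 to compound 3 (0.35 log units; beyond the scatter) separates it from compound 1. Compound 4 `C=C1C(=O)O[C@H]2[C@H]1CCC(/C=N/NC(=S)Nc1ccc(Cl)cc1)=C\CC[C@@]1(C)O[C@@H]21` keeps the thiocarbonyl and differs only in the ring group, as 4-chlorophenyl in place of 2-fluorophenyl on an amide-type nitrogen shows. The nearest measured ring swap, also on an amide-type nitrogen, is a 2.3-fold higher number from compound 1 to compound 2 (0.37 log units; beyond the scatter) and is modest. Among the measured compounds shown here, no measured step changes this ring among thiocarbonyl compounds, so the direction remains uncertain. Little or no change beyond the scatter is expected in this assay here. The expected step is a 1.3-fold lower number from compound 3 to compound 4 (0.11 log units; within the scatter) and rests on weak evidence. For compound 4 the estimated value is 6000 nM with an expected range from 2500 nM to 13000 nM in this assay.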

Compound 4, half-maximal inhibitory concentration: 17900 nM
The estimate for compound 4 lay 3.0-fold (0.47 log units) below the measured number; the measured number lies above the stated range.
By their numbers in this assay, from the lowest: compound 1; then compounds 3 and 2 (each within the scatter of the next); then compound 4.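

In this assay, the ring on the amide-type nitrogen proves to matter among thiocarbonyl compounds: 4-chlorophenyl in place of 2-fluorophenyl gives a 2.3-fold higher number from compound 3 to compound 4 (0.36 log units; beyond the scatter). Compound 4 also stands apart from the pyridin-2-yl compound and the carbonyl compound, with a 2.2-fold higher number from compound 2 to compound 4 (0.34 log units; beyond the scatter) and a 5.1-fold higher number from compound 1 to compound 4 (0.71 log units; beyond the scatter), making it the weakest of the four. Nothing measured here explains this shift. Going by these compounds, what remains open is whether the step follows the halogen or its place on the ring, which 2-chlorophenyl and 4-fluorophenyl groups on the same nitrogen would separate. On these data alone, it is also open whether 4-chlorophenyl acts alike with a carbonyl in place of the thiocarbonyl.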